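Double-bond geometry step from compound 3 to compound 4

A few compounds are considered here, and "the series" means these few. Any claim that something is new, unique, unknown or untested is made for them only; others in the source may bear on it.

The series is read in a functional assay on SW-620 cells (Homo sapiens) for antiproliferative activity, read by MTT assay, with a stated time of 3 days; a higher number here means a weaker inhibitor, a lower number a stronger inhibitor. Compound 1 `CCCCCCCCC#Cc1cn(C/C=C/CN2C(=O)c3ccccc3C2=O)c(=O)[nH]c1=O` gives 87000 nM. Compound 2 `CCCCc1ccc(C#Cc2cn(C/C=C/CN3C(=O)c4ccccc4C3=O)c(=O)[nH]c2=O)cc1` carries 4-butylphenyl in place of octyl on a triple-bonded carbon. For compound 2 the assay reports only a limit, > 100000 nM. The step of an at least 1.1-fold higher number from compound 1 to compound 2 (0.06 log units; that floor lies within the scatter) stays within the scatter. Compound 3 `O=C1c2ccccc2C(=O)N1C/C=C\Cn1cc(C#CCCc2ccccc2)c(=O)[nH]c1=O` likewise stands at a limit, > 100000 nM. Two of the three values are limits (the limit of > 100000 nM in this assay, at which 2 of the 3 values shown sit), so compound 3 cannot be placed more precisely than at the weak end of the numbers shown.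

Compound 4 `O=C1c2ccccc2C(=O)N1C/C=C/Cn1cc(C#CCCc2ccccc2)c(=O)[nH]c1=O` differs from compound 3 only in configuration: the two compounds have the same atoms and bonds and differ only in configuration as drawn: 1 of 1 stereo elements differ; a double bond is drawn Z in compound 3 and E in compound 4. Among the compounds with values here, no measured step changes the double-bond geometry; the single measured step concerns the alkyne substituent and bears only loosely on this change. Compound 1 and compound 2 both carry the E-drawn linker, and one gives a number while the other stands at a limit. Compound 4 is therefore expected to remain weak, with the step of a number no higher from compound 3 to compound 4 (the limit leaves the size open) estimated to stay within the scatter of the limit. The estimate for compound 4 is 100000 nM, ranging from 40000 nM to 250000 nM.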

Compound 4, half-maximal inhibitory concentration: 11000 nM
Compound 4: the middle estimate sits 9.1-fold (0.96 log units) above what was measured, and the stated range ends above it.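

In this assay there is an at least 9.0-fold lower number from compound 3 to compound 4 (0.95 log units; beyond the scatter), and double-bond geometry alone accounts for it: the fact that compounds 3 and 4 differ only in the configuration as drawn. With the E-drawn linker held, the alkyne substituent also counts, with an at least 9.0-fold lower number from compound 2 to compound 4 (0.95 log units; beyond the scatter) and a 7.9-fold lower number from compound 1 to compound 4 (0.90 log units; beyond the scatter), so phenethyl gives the lowest number of the three substituents carried on that linker. As far as these compounds go, the steps from compound 2 and from compound 3 each start from a limit, so their full size stays open: the limit of > 100000 nM in this assay, at which 2 of the 4 values shown sit.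

From the compounds shown here alone, whether the E-drawn linker also gives the lower number with octyl or 4-butylphenyl on the triple-bonded carbon remains open. Also open, going by these compounds, is how this assay would read with an amine or a carboxylic acid in place of the phenyl of the phenethyl group.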